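Methoxy on the Distal Phenyl of a Benzothiazole Amide

The source may hold more compounds than are shown below. What is called first, only, known or untested is meant among the compounds shown, and "the series" means these compounds.

Of the compounds shown here, two have been measured. Compound 1 `O=C(Nc1nc2ccc(Cl)cc2s1)c1cn(-c2ccccc2)nc1-c1ccccc1` gives 3690 nM in a functional assay on PC-3 cells (Homo sapiens) for cytotoxicity, read by MTT assay, with a stated time of 72 h (a higher number here means a weaker inhibitor, a lower number a stronger inhibitor), and compound 2 `Cc1ccc2nc(NC(=O)c3cn(-c4ccccc4)nc3-c3ccccc3)sc2c1` gives 15700 nM in this assay. For the measured compounds named here, the one step recorded between them, a 4.3-fold higher number from compound 1 to compound 2 (0.63 log units; beyond the scatter), leaves compound 2 with the highest of the two numbers, its nearest neighbour being compound 1.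

Compound 3 `COc1ccc(-c2nn(-c3ccccc3)cc2C(=O)Nc2nc3ccc(C)cc3s2)cc1` differs from compound 2 in a single place: methoxy in place of hydrogen on an aromatic carbon. Going by the values given here, no measured step bears on this change. Among the compounds with values here, the only recorded step, a 4.3-fold higher number from compound 1 to compound 2 (0.63 log units; beyond the scatter), concerns the substituent on the other aromatic ring of the shared core, and it says nothing about a methoxy entering the phenyl. Within the data shown here, with no step to go on, the author expects no change beyond the scatter, so that a 1.0-fold lower number from compound 2 to compound 3 (0.02 log units; within the scatter) is the estimated step in this assay. The number expected for compound 3 is therefore 15000 nM, with a range from 5000 nM to 45000 nM, and the actual value is now awaited.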

Compound 3, half-maximal inhibitory concentration: 15900 nM
Estimate against measurement, compound 3: 1.1-fold (0.03 log units) below, and the stated range covers the measured number.
By their numbers in this assay, from the lowest: compound 1; then compounds 2 and 3 (each within the scatter of the next).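

Going from phenyl to 4-methoxyphenyl, with the methoxy para to a large group on a six-membered aromatic ring of carbon only, gives a 1.0-fold higher number from compound 2 to compound 3 (0.01 log units; within the scatter) in this assay. For the compounds shown here, this is the first reading of this ring, and at this place, on the methyl-bearing core of compound 2, a methoxy can replace hydrogen without moving the number beyond the scatter, whereas the earlier exchange of chloro for methyl on the other aromatic ring gave a 4.3-fold higher number from compound 1 to compound 2 (0.63 log units; beyond the scatter). Nothing measured here bears on why the methoxy leaves the number where it stands, so the result records a tolerated change and offers no explanation for it.

The compounds shown leave open whether a hydroxyl, an amine, a carboxylic acid or a longer chain such as ethoxy at this same place would also leave the number within the scatter, or would shift it in either direction. They also leave open whether the methoxy would read the same on the chloro-bearing core of compound 1, where the number starts lower, or at another place on the same phenyl.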